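The compounds below may be only part of what the source reports. "The series", "measured", "known", "first", "only" and "open" are said of these compounds alone.

Compound 1 `Nc1ccccc1NC(=O)c1ccc(CSC(=S)N2CCN(Cc3ccccn3)CC2)cc1`: 14.2%
Compound 2 `N#Cc1ccc(N2CCN(C(=S)SCc3ccc(C(=O)Nc4ccccc4N)cc3)CC2)cc1`: 71.6%

In a functional assay on HeLa cells (Homo sapiens) for antiproliferative activity, read by CCK-8 assay, with a stated time of 72 h, tested at 2 uM (on this read-out higher numbers stand for a stronger effect at the one concentration tested and lower numbers for a weaker effect), compound 2 gives 71.6% and stands highest of the two numbers; its nearest neighbour is compound 1, which gives 14.2%. Compound 3 `Nc1ccccc1NC(=O)c1ccc(CSC(=S)N2CCN(Cc3cccnc3)CC2)cc1` differs from compound 2 in one place: (pyridin-3-yl)methyl in place of 4-cyanophenyl on an amine nitrogen in a ring. Among the compounds with values here, one measured step bears on this change: a number 57.4 percentage points higher from compound 1 to compound 2 (beyond the scatter). Since compound 3 carries a (pyridin-3-yl)methyl where compound 1 carries a (pyridin-2-yl)methyl, that step is expected to be largely undone, and a large drop is expected, a number 53.6 percentage points lower from compound 2 to compound 3 (beyond the scatter). For compound 3 the estimate is 18%, with a range from 5% to 40%.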

Compound 3, a percentage reported as inhibition, at one concentration (the size of the read-out at that concentration, not a potency): 69.7%
Compound 3: middle estimate off by 51.7 percentage points, on the low side; the whole stated range lies below it.
By their numbers in this assay, from the lowest: compound 1; then compounds 3 and 2 (each within the scatter of the next).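

In this assay a change of a number 1.9 percentage points lower from compound 2 to compound 3 (within the scatter) means that (pyridin-3-yl)methyl and 4-cyanophenyl on this amine nitrogen in a ring are not told apart, so carrying a pyridine ring there does not by itself go with the weak effect of compound 1. The step of a number 55.5 percentage points higher from compound 1 to compound 3 (beyond the scatter) ties that large difference to pyridin-3-yl in place of pyridin-2-yl on the saturated chain carbon. Nothing measured here accounts for this difference.

On these data alone, whether a pyridin-4-yl or a plain phenyl on that chain carbon would stand with compound 3 or with compound 1 remains open.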